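The source may hold more compounds than are shown below. What is called first, only, known or untested is meant among the compounds shown, and "the series" means these compounds.

Measured compounds, cytotoxicity in an ADME assay on HFF cells (Homo sapiens) for cytotoxicity, read by MTT assay, with a stated time of 72 h; on this read-out lower numbers stand for stronger inhibition and higher numbers for weaker inhibition:
compound 1 `CC(C)(C)c1cn(C[C@H](O)[C@H]2OC(=O)C(OCc3ccccc3)=C2OCc2ccccc2)nn1`: compound 1 gives 13300 nM
compound 2 `COc1ccc(-c2cn(C/C=C3\OC(=O)C(OCc4ccccc4)=C3OCc3ccccc3)nn2)cc1`: compound 2 gives > 100000 nM, a limit of the assay
compound 3 `O=C1O[C@H]([C@@H](O)Cn2cc(-c3cc(F)cc(F)c3)nn2)C(OCc2ccccc2)=C1OCc1ccccc1`: compound 3 gives > 100000 nM, a limit of the assay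

Within the data shown here, compound 1 holds the only number in this assay; the other two results are limits (the limit of > 100000 nM in this assay, at which 2 of the 3 values shown sit). The unmeasured compound 4 `COc1ccccc1-c1cn(C[C@H](O)[C@H]2OC(=O)C(OCc3ccccc3)=C2OCc2ccccc2)nn1` differs from compound 1 in one place: 2-methoxyphenyl in place of tert-butyl on an aromatic carbon.

Among the measured compounds shown here, one measured step bears on this change, the replacement of the same tert-butyl by an aryl group: an at least 7.5-fold higher number from compound 1 to compound 3 (0.87 log units; beyond the scatter). Compound 2 carries a different aryl group and a changed linker and also sits at the limit, so nothing on this series shows an aryl group at this position lowering the number. For compound 4 the step is therefore expected to run the same way, toward a weaker cytotoxicity, with a fair chance that only a limit is reported.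

Compound 4 is estimated at 80000 nM in this assay, expected between 25000 nM and 250000 nM. That estimate means an expected step of a 6.0-fold higher number from compound 1 to compound 4 (0.78 log units; beyond the scatter).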

Compound 4, half-maximal inhibitory concentration: 50 nM
Compound 4: the middle estimate sits 1600-fold (3.20 log units) above what was measured; measured number below the stated range.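

In this assay, an aryl group on this aromatic carbon does not fix the direction of the change: 2-methoxyphenyl in place of tert-butyl gives a 270-fold lower number from compound 1 to compound 4 (2.42 log units; beyond the scatter), opposite in direction to the step seen with 3,5-difluorophenyl. The choice of aryl group therefore matters greatly at this position, with 2-methoxyphenyl in place of 3,5-difluorophenyl giving an at least 2000-fold lower number from compound 3 to compound 4 (3.30 log units; beyond the scatter). That step has only a bound, since compound 3 stands at a limit of the assay: the limit of > 100000 nM in this assay, at which 2 of the 4 values shown sit.

The compounds shown do not separate the contribution of the methoxy group from that of the phenyl ring carrying it, and compound 2 differs from compound 4 in more than one place. An unsubstituted phenyl or a 2-aminophenyl group on this carbon would test that separation.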